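Compound 3 and its 3-(4-methylpiperazin-1-yl)propyl homologue

This account rests on a few compounds, and the source may have more. Where it says the series, first, only, none or still open, it means among the compounds named here.

Compound 1 `CCn1c(N)c(-c2nc3ccccc3[nH]2)c2nc(C#N)c(C#N)nc21`, compound 2 `CN(C)CCn1c(N)c(-c2nc3ccccc3[nH]2)c2nc(C#N)c(C#N)nc21` and compound 3 `CN1CCN(CCn2c(N)c(-c3nc4ccccc4[nH]3)c3nc(C#N)c(C#N)nc32)CC1` share one core and differ in the group at the end of the saturated chain. In a functional assay on HeLa cells (Homo sapiens) for antiproliferative activity, read by MTT assay, with a stated time of 48 h (a higher number here means a weaker inhibitor, a lower number a stronger inhibitor), compound 1 gives > 50000 nM, which is a limit. Among the compounds with values here, compound 2 gives 8880 nM, the only true number among the three. Compound 3 gives > 50000 nM, again only a limit.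

Compound 4 `CN1CCN(CCCn2c(N)c(-c3nc4ccccc4[nH]3)c3nc(C#N)c(C#N)nc32)CC1` carries 3-(4-methylpiperazin-1-yl)propyl where compound 3 carries 2-(4-methylpiperazin-1-yl)ethyl: (4-methylpiperazin-1-yl)methyl in place of 4-methylpiperazin-1-yl on a saturated chain carbon, two bonds along the chain from an aromatic nitrogen.

Within the data shown here, no measured step changes the chain length, so the nearest guides concern the end group. The data show an at least 5.6-fold lower number from compound 1 to compound 2 (0.75 log units; beyond the scatter) and a step that the two limits leave unreadable from compound 1 to compound 3. They also show an at least 5.6-fold higher number from compound 2 to compound 3 (0.75 log units; beyond the scatter), and compound 4 keeps the end group of that step, so weak activity is expected to persist in this assay.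

The expected change is small, and the result may again be only a limit: an at least 1.2-fold lower number from compound 3 to compound 4 (0.09 log units; that floor lies within the scatter). The estimate for compound 4 is 40000 nM, with an expected range of 12000 nM to 90000 nM.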

Compound 4, half-maximal inhibitory concentration: 15600 nM
The estimate for compound 4 lay 2.6-fold (0.41 log units) above the measured number; the range from low to high includes it.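

In this assay, within the data shown here, the 3-(4-methylpiperazin-1-yl)propyl chain gives a true number where the 2-(4-methylpiperazin-1-yl)ethyl chain gave only a limit, the first change of chain length in this set: an at least 3.2-fold lower number from compound 3 to compound 4 (0.50 log units; beyond the scatter). The 4-methylpiperazin-1-yl end group therefore does not hold the activity at the limit on every chain, and on the longer chain it cannot be told apart from the dimethylamino group on the shorter one: a 1.8-fold higher number from compound 2 to compound 4 (0.24 log units; within the scatter). A further step reads an at least 3.2-fold lower number from compound 1 to compound 4 (0.50 log units; beyond the scatter), and both this step and the one from the 2-(4-methylpiperazin-1-yl)ethyl chain are floors only, since each starts from a limit: the limit of > 50000 nM in this assay, at which 2 of the 4 values shown sit.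

As far as these compounds go, what a 3-(dimethylamino)propyl chain would give remains open, so the effect of chain length rests on a single pair. From the compounds shown here alone, whether a butyl chain extends the trend, or whether a morpholine end group behaves like the 4-methylpiperazin-1-yl group, also remains unknown.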